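Working notes: tolerance of the shared core in SR cells

The compounds below may be only part of what the source reports. "The series", "measured", "known", "first", "only" and "open" are said of these compounds alone.

Measured compounds:
compound 1 `CCOC(=O)[C@H](CCC(=O)O)NC(=O)c1ccc(CNc2nc3cc(N)cc(N)c3nc2-c2ccccc2)cc1` — 93300 nM
compound 2 `Nc1cc(N)c2nc(-c3ccccc3)c(NCc3ccc(Cl)c(Cl)c3)nc2c1` — a limit only
compound 3 `CCOC(=O)[C@H](CCC(=O)O)NC(=O)c1ccc(Sc2nc3cc(N)cc(N)c3nc2-c2ccccc2)cc1` — a limit only

In a functional assay on SR cells (Homo sapiens) for inhibition, read by sulforhodamine B assay, with a stated time of 48 h (a lower number here means that less compound is tolerated, a higher number that more compound is tolerated), compound 1 gives 93300 nM. For compound 2 the assay reports only a limit, < 100000 nM. For compound 3 the assay likewise reports only a limit, < 100000 nM. For the measured compounds named here, compound 2 thus stands at the limit of < 100000 nM in this assay, at which 2 of the 3 values shown sit, and no step between measured compounds differing in a single place is available from these three.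

Compound 4 `COc1ccc(CNc2nc3cc(N)cc(N)c3nc2-c2ccccc2)cc1` differs from compound 2 by 4-methoxyphenyl in place of 3,4-dichlorophenyl on a saturated chain carbon bound to a nitrogen on an aromatic ring. Across this change no shift beyond the usual scatter is expected; the estimated step is a step that the limit leaves unreadable from compound 2 to compound 4. Compound 4 is expected to give 90000 nM, with a range of 30000 nM to 100000 nM, and the assay may well again report only a limit.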

Compound 4, concentration lethal to 50% of the cells: < 100000 nM
Compound 4 gave a limit, no number (the forecaster's own chance of this, stated with the estimate: 55%); the middle value lies beyond the limit too.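

Compound 2 and compound 4 each give only a limit in this assay, and the step between them cannot be read. On these data alone, whether 4-methoxyphenyl in place of 3,4-dichlorophenyl changes tolerance at all stays open, as does the actual value of either compound.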